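A few compounds are considered here, and "the series" means these few. Any claim that something is new, unique, unknown or untested is made for them only; others in the source may bear on it.

Measured so far in a functional assay on HepG2 cells (Homo sapiens) for cytotoxicity, read by MTT assay, with a stated time of 96 h; a higher number here means that more compound is needed for the effect, a lower number that less compound is needed:
compound 1 `COc1ccc(-c2[nH]c3ccc(OC)cc3c2/C=C(\C#N)S(=O)(=O)c2ccccc2)cc1` gives 6400 nM
compound 2 `CC(=O)/C(=C/c1c(-c2ccccc2)[nH]c2ccccc12)C(=O)c1ccccc1` gives 79000 nM

Of these two, compound 1 stands at the lower number; compound 2 sits higher, and the gap between them is beyond the usual scatter. Compound 3 `COc1ccc(-c2[nH]c3ccccc3c2/C=C(\C#N)S(=O)(=O)c2ccccc2)cc1` differs from compound 1 in one place: hydrogen in place of methoxy on an aromatic carbon. Going by the values given here, no pair of measured compounds shows what such a change does here, so the step of a 1.3-fold higher number from compound 1 to compound 3 (0.10 log units; within the scatter) is expected to be small, at most slightly upward and possibly none beyond the scatter. Compound 3 is therefore estimated at 8000 nM, with a range from 2500 nM to 25000 nM.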

Compound 3, half-maximal effective concentration: 11000 nM
Estimate against measurement, compound 3: 1.4-fold (0.14 log units) below, within the range that was stated.
By their numbers in this assay, from the lowest: compounds 1 and 3 (each within the scatter of the next); then compound 2.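

In this assay, going by these compounds alone, hydrogen in place of methoxy on this aromatic carbon gives a 1.7-fold higher number from compound 1 to compound 3 (0.24 log units; within the scatter) and so offers the first direct reading of this change. At this position of the shared core, the methoxy can be lost without a shift that stands out from the scatter. Nothing measured here bears on why this is so. Going by these compounds, whether an amine or a carboxylic acid on the same aromatic carbon would move the number remains open. So does whether this change would behave alike on a different core.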